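Metabolic Stability After Rearranging Fluorines and Methoxy

This account rests on a few compounds, and the source may have more. Where it says the series, first, only, none or still open, it means among the compounds named here.

Measured compounds:
Compound 1 `CC(=O)c1ccc(-c2ccc(CO[C@@H]3COc4nc([N+](=O)[O-])cn4C3)cc2)cc1`: 36%
Compound 2 `O=[N+]([O-])c1cn2c(n1)OC[C@@H](OCc1ccc(-c3ccc(OC(F)F)cc3)cc1)C2`: 94%

In an ADME assay on microsomes from liver (Homo sapiens) for metabolic stability, read by LC-MS, with a stated time of 1 h (a higher number here means that more of the compound is left, a lower number that less of the compound is left), compound 1 gives 36% and compound 2 gives 94%. Compound 2 stands highest of the two numbers; its nearest neighbour is compound 1, and the step of a number 58 percentage points higher from compound 1 to compound 2 (beyond the scatter) lies beyond the scatter.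

Compound 3 `COc1c(F)cc(F)cc1-c1ccc(CO[C@@H]2COc3nc([N+](=O)[O-])cn3C2)cc1` has not yet been measured. It differs from compound 2 in one place: 3,5-difluoro-2-methoxyphenyl in place of 4-(difluoromethoxy)phenyl on an aromatic carbon. The two have the same atoms, joined differently.

Going by the values given here, the only measured step, a number 58 percentage points higher from compound 1 to compound 2 (beyond the scatter), exchanges an acetyl group for a difluoromethoxy group, whereas the step to compound 3 keeps the same atoms on the outer ring and only rearranges them. That step therefore bears on the present one only loosely: it shows that a change on this outer ring can move the number a great deal, but it gives no direction for a rearrangement. Compound 2 already sits near the top of the scale, so there is more room downward than upward. Compound 3 is thus expected to fall somewhat below compound 2, by a number 29 percentage points lower from compound 2 to compound 3 (beyond the scatter), a step of uncertain size. Compound 3 is estimated at 65%, within a range from 30% to 95%.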

Compound 3, percent of the compound remaining: 72%
For compound 3 the middle estimate is 7 percentage points below the measured one; low and high end bracket the measured number.
By their numbers in this assay, from the lowest: compound 1; then compound 3; then compound 2.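

In this assay, this place on the biaryl proves sensitive to arrangement alone: with the same atoms, 3,5-difluoro-2-methoxyphenyl in place of 4-(difluoromethoxy)phenyl gives a number 22 percentage points lower from compound 2 to compound 3 (beyond the scatter), so the atom make-up of the group and its counts of heavy atoms and hydrogen-bond acceptors do not by themselves set the number here. The rearranged group nevertheless keeps much of the advantage over the acetyl-bearing ring, with 3,5-difluoro-2-methoxyphenyl in place of 4-acetylphenyl giving a number 36 percentage points higher from compound 1 to compound 3 (beyond the scatter), and so both fluorine-bearing rings stand above the 4-acetylphenyl ring among these three compounds, with no compound going against that order. Nothing available gives a reason for either step.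

Going by these compounds, it remains open whether the lower number of compound 3 follows from the changed attachment of the oxygen, from the loss of fluorine on the methoxy carbon, or from the fluorines on the ring, since these changes arrive together in one step. On these data alone, how a ring carrying a nitrile, an amine or a carboxylic acid would stand at this place is also open.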